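Chlorine placement on the aryl ring: expected value for compound 3

The source may report more compounds than this note shows. Statements on the series, on what has been measured and on what is new or still open speak of the compounds shown alone.

Among the compounds with values here, in an assay on isolated protein for inhibition of histone deacetylase 8 (Homo sapiens), read by fluorescence, with a stated time of 5 min, tested at 1 uM (a higher number here means a stronger effect of the compound at the concentration tested, a lower number a weaker effect), compound 2 `CCCNNC(=O)c1cnc(NCc2ccc(Cl)cc2)nc1` gives 62%, the higher of the two numbers known so far. Compound 1 `CCCNNC(=O)c1cnc(NCc2cc(Cl)ccc2Cl)nc1` gives 33%, a gap beyond the usual scatter. Compound 3 `CCCNNC(=O)c1cnc(NCc2ccccc2Cl)nc1` awaits measurement; it differs from compound 2 by 2-chlorophenyl in place of 4-chlorophenyl on a saturated chain carbon bound to a nitrogen on an aromatic ring. Within the data shown here, no single-change step between measured compounds is available to calibrate this change. A moderate drop is expected, since compound 1, which also carries chlorine on its aryl ring, gives only 33%. The expected step is a number 17 percentage points lower from compound 2 to compound 3 (beyond the scatter). Compound 3 is estimated at 45%, within 25% to 65%.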

Compound 3, a percentage reported as inhibition, at one concentration (the size of the read-out at that concentration, not a potency): 43%
The estimate for compound 3 lay 2 percentage points above the measured number, within the range that was stated.
By their numbers in this assay, from the lowest: compounds 1 and 3 (each within the scatter of the next); then compound 2.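

In this assay, 2-chlorophenyl in place of 4-chlorophenyl gives a number 19 percentage points lower from compound 2 to compound 3 (beyond the scatter) with the atom count unchanged, so the placement of chlorine on this ring can be read at this position. Hydrogen in place of chloro on an aromatic carbon gives a number 10 percentage points higher from compound 1 to compound 3 (within the scatter) and so the extra chloro of compound 1 brings no readable difference from compound 3. Nothing available explains either step.

Open, on these data alone, is how a phenyl ring without chlorine would compare with compound 2. Also open, as far as these compounds go, is whether a methoxy group in place of chlorine would keep the read-out.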